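A few compounds are considered here, and "the series" means these few. Any claim that something is new, unique, unknown or untested is made for them only; others in the source may bear on it.

Within the data shown here, in an ADME assay on MT4 cells (Homo sapiens) for cytotoxicity, read by MTT assay, with a stated time of 4 days (a higher number here means that more compound is tolerated, a lower number that less compound is tolerated), compound 2 `CC(c1cc(=O)[nH]c(N(C)C)n1)c1c(F)cccc1F` gives 89000 nM, the only actual number in the set. Compound 1 `CN(C)c1nc(Cc2c(F)cccc2F)cc(=O)[nH]1` gives > 94000 nM, which is a limit. Compound 3 `CCCN(C)c1nc(C(C)c2c(F)cccc2F)cc(=O)[nH]1` gives > 81000 nM, also a limit. Compound 4 `CCC(c1cc(=O)[nH]c(N(C)C)n1)c1c(F)cccc1F` differs from compound 2 by methyl in place of hydrogen on a saturated chain carbon, two bonds along the chain from two aromatic carbons: methyl to ethyl, on a saturated chain carbon, two bonds along the chain from two aromatic carbons. The closest measured change is methyl in place of hydrogen on a saturated chain carbon bound to two aromatic carbons, which gave an at least 1.0-fold lower number from compound 1 to compound 2 (0.02 log units; that floor lies within the scatter). Ethyl in place of hydrogen on a saturated chain carbon bound to a nitrogen on an aromatic ring gave a step that the limit leaves unreadable from compound 2 to compound 3. No step beyond the scatter is therefore expected in this assay. The expected result is a 1.1-fold lower number from compound 2 to compound 4 (0.05 log units; within the scatter). Compound 4 is estimated at 80000 nM, with an expected range of 40000 nM to 100000 nM.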

Compound 4, half-maximal cytotoxic concentration: 73000 nM
The estimate for compound 4 lay 1.1-fold (0.04 log units) above the measured number, and the stated range covers the measured number.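

In this assay, among these compounds, methyl in place of hydrogen on a saturated chain carbon, two bonds along the chain from two aromatic carbons, gives a 1.2-fold lower number from compound 2 to compound 4 (0.09 log units; within the scatter) as the first step between two actual numbers. A further comparison gives an at least 1.2-fold lower number from compound 1 to compound 4 (0.10 log units; that floor lies within the scatter) as a step with only a floor. Compound 1 stands at a limit, which is why that step is only a floor: the limit of > 94000 nM in this assay, at which 1 of the 4 values shown sits.

Still open, as far as these compounds go, is whether a longer chain, an amine or a carboxylic acid on this carbon would give a step beyond the scatter in this assay and so shift the tolerated concentration.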